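The source may hold more compounds than are shown below. What is called first, only, known or untested is meant among the compounds shown, and "the series" means these compounds.

Compound 2 `O=C(/C=C/c1ccc([N+](=O)[O-])cc1)c1ccc(N2C(=O)C=CC2=O)cc1` sits at the weak end of what has been measured: in a functional assay on L1210 cells (Mus musculus) for cytotoxicity (on this read-out lower numbers stand for stronger inhibition and higher numbers for weaker inhibition), compound 2 gives > 500000 nM, which is a limit of the assay rather than a number. Compound 1 `O=C(/C=C/c1ccc(Cl)cc1)c1ccc(N2C(=O)C=CC2=O)cc1` carries chloro where compound 2 carries nitro; in this assay compound 1 gives 7300 nM. Within the data shown here, the only measured step, an at least 68-fold higher number from compound 1 to compound 2 (1.83 log units; beyond the scatter), shows that an exchange at this position can move the read-out a long way, and the limit of > 500000 nM in this assay, at which 1 of the 2 values shown sits, marks that the second value is a limit. Compound 3 `O=C(O)c1ccc(/C=C/C(=O)c2ccc(N3C(=O)C=CC3=O)cc2)cc1` differs from compound 2 by carboxy in place of nitro on an aromatic carbon. Among the measured compounds shown here, no measured pair exchanges nitro for carboxy, so the size and direction of the step are uncertain. Since compound 2 already gives > 500000 nM in this assay, a further weakening could not be seen, and an improvement would have to be large to show. The estimate for compound 3 is 300000 nM, with a range from 30000 nM to 1000000 nM. This estimated step, an at least 1.6-fold lower number from compound 2 to compound 3 (0.22 log units; that floor lies within the scatter), is expected to leave compound 3 near the limit, and a limit result is thought about as likely as a number.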

Compound 3, half-maximal inhibitory concentration: 135000 nM
Estimate against measurement, compound 3: 2.2-fold (0.35 log units) above, and the stated range covers the measured number.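

The exchange of nitro for carboxy at this position gives an at least 3.7-fold lower number from compound 2 to compound 3 (0.56 log units; beyond the scatter) in this assay and so replaces a bare limit with a number, which shows that this position can be read on the weak side of chloro. Chloro still gives the lowest number of the three, for the change from chloro to carboxy gives an 18-fold higher number from compound 1 to compound 3 (1.27 log units; beyond the scatter) and thus joins the change from chloro to nitro as a second replacement that moves the number up beyond the scatter. The value of compound 2 is a limit and not a number, which leaves the step from it to carboxy with a floor only: the limit of > 500000 nM in this assay, at which 1 of the 3 values shown sits.

The compounds shown leave open whether any group at this position can give a lower number than chloro, and three groups are too few to show a trend. A fluoro or bromo atom, a methoxy group or an amine here, or a methyl ester in place of the carboxylic acid, would show whether chloro stands alone or belongs to a wider set of groups.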